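A few compounds are considered here, and "the series" means these few. Any claim that something is new, unique, unknown or untested is made for them only; others in the source may bear on it.

Three related compounds have been measured in a functional assay on HCT-116 cells (Homo sapiens) for inhibition; a higher number here means a weaker inhibitor, a lower number a stronger inhibitor. There, compound 1 (`O=C1NC(=O)c2c1c1c3ccccc3ncc1c1[nH]c3ccccc3c21`) gives 390 nM, compound 2 (`O=C1NC(=O)c2c1c1c3cccnc3ccc1c1[nH]c3ccccc3c21`) gives 430 nM, and compound 3 (`O=C1NC(=O)c2c1c1c3ccncc3ccc1c1[nH]c3ccccc3c21`) gives 130 nM. Compound 1 thus stands level with compound 2 within the scatter, while compound 3 has a lower number, beyond the scatter. Compound 4 (`O=C1NC(=O)c2c1c1c3ccccc3ncc1c1[nH]c3cc(Cl)ccc3c21`) keeps the core of compound 1 and adds one change, chloro in place of hydrogen on an aromatic carbon. Among the measured compounds shown here, no measured pair shows what such a change does, so the expectation is cautious. The expected change is small, a 1.3-fold lower number from compound 1 to compound 4 (0.11 log units; within the scatter), and is not expected to lie beyond the scatter. In this assay, compound 4 is estimated at 300 nM, with an expected range of 90 nM to 1000 nM.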

Compound 4, half-maximal inhibitory concentration: 650 nM
The estimate for compound 4 lay 2.2-fold (0.34 log units) below the measured number; low and high end bracket the measured number.
By their numbers in this assay, from the lowest: compound 3; then compounds 1, 2 and 4 (each within the scatter of the next).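

In this assay, among the compounds shown here, chloro in place of hydrogen on an aromatic carbon, meta to a fused ring and para to a fused ring, gives the first readable step for this position (a 1.7-fold higher number from compound 1 to compound 4 (0.22 log units; within the scatter)). Compound 4 therefore stands level with compound 1, and this single pair shows no clear effect of the change. No supporting data bear on this result. As far as these compounds go, whether an amine or a methoxy group at the same position would leave the number level remains open, as does whether chloro would behave alike on the core of compound 3.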